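Bromophenyl for methoxyphenyl on the shared core: compound 4

A few compounds are considered here, and "the series" means these few. Any claim that something is new, unique, unknown or untested is made for them only; others in the source may bear on it.

Compound 2 `COc1ccc(-c2cc(COC(Cc3cn(C4CCN(Cc5ccc([N+](=O)[O-])cc5)CC4)nn3)c3ccc(Br)cc3)on2)cc1` gives 2000 nM in a functional assay on Huh-7 cells (Homo sapiens) for cytotoxicity, with a stated time of 48 h; on this read-out higher numbers stand for weaker inhibition and lower numbers for stronger inhibition. Compound 1 `O=[N+]([O-])c1ccc(CN2CCC(n3cc(CC(OCc4cc(-c5ccc(Br)cc5)no4)c4ccc(Br)cc4)nn3)CC2)cc1` gives 2000 nM in this assay, and compound 3 `N#Cc1ccc(-c2cc(COC(Cc3cn(C4CCN(Cc5ccc([N+](=O)[O-])cc5)CC4)nn3)c3ccc(Br)cc3)on2)cc1` gives 5000 nM. Compound 2 thus stands level with compound 1: no change at the digits printed from compound 1 to compound 2 (within the scatter), the methoxy in place of bromo on an aromatic carbon leaving the number where it was. Against this, a 2.5-fold higher number from compound 2 to compound 3 (0.40 log units; beyond the scatter) and a 2.5-fold higher number from compound 1 to compound 3 (0.40 log units; beyond the scatter); these are the two steps that carry cyano onto that aromatic carbon, and both lie beyond the scatter.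

Compound 4 `O=[N+]([O-])c1ccc(CN2CCC(n3cc(CC(OCc4cc(-c5ccccc5Br)no4)c4ccc(Br)cc4)nn3)CC2)cc1` differs from compound 2 in one place: 2-bromophenyl in place of 4-methoxyphenyl on an aromatic carbon. For the measured compounds named here, the measured step that bears on this exchange is the one from compound 1 to compound 2, where bromo and methoxy on the aromatic carbon gave the same number within the scatter. The cyano steps point upward but do not involve the group that enters here. Going by the values given here, no measured compound carries a 2-bromophenyl on the shared core, so the reading rests on the bromo-for-methoxy comparison alone. A step within the scatter, in either direction, is therefore expected in this assay. Compound 4 is expected at 2000 nM, with a range of 1000 nM to 4500 nM. The expected step is no change at the digits printed from compound 2 to compound 4 (within the scatter).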

Compound 4, half-maximal inhibitory concentration: > 25000 nM
Compound 4: a limit, no number; the forecaster's own chance of this, stated with the estimate: 5%; at least 12-fold (1.09 log units) between middle value and limit.
By their numbers in this assay, from the lowest: compounds 1 and 2 (each within the scatter of the next); then compound 3. At a limit, above all of these: compound 4.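

Compound 4 is held at a limit of the assay, not a number: the limit of > 25000 nM in this assay, at which 1 of the 4 values shown sits.

In this assay, the sharpest contrast keeps bromo on the phenyl group and exchanges 4-bromophenyl for 2-bromophenyl on the aromatic carbon of the five-membered ring: an at least 12-fold higher number from compound 1 to compound 4 (1.09 log units; beyond the scatter). The compounds with a 4-substituted phenyl group showed only how the substituent on that phenyl group reads out, whereas this pair shows that 2-bromophenyl and 4-bromophenyl are not interchangeable at this position, and an at least 12-fold higher number from compound 2 to compound 4 (1.09 log units; beyond the scatter) and an at least 5.0-fold higher number from compound 3 to compound 4 (0.69 log units; beyond the scatter) point the same way.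

Compound 4 is the only compound shown with 2-bromophenyl, so the compounds shown do not separate the place of the bromo from the identity of that group, and a single exchange cannot establish a rule for the position. An unsubstituted phenyl group, or a methyl group in place of the whole aryl group, would show how much of the aryl group this position needs in this series.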